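Cyclopentyl Amide in Place of Dimethylphenyl on Shared Core

The source may hold more compounds than are shown below. What is called first, only, known or untested is meant among the compounds shown, and "the series" means these compounds.

Compound 3 `Cc1ccc(C(=O)Nc2cc(-c3ccccc3)nn2-c2ccccc2)cc1C` holds the lowest number among the three compounds measured in an assay on HEK293 cells for displacement of a labelled ligand from metabotropic glutamate receptor 5 (Rattus norvegicus) (on this read-out higher numbers stand for weaker inhibition and lower numbers for stronger inhibition), where compound 3 gives 430 nM. Compound 1 `O=C(Nc1cc(-c2ccccc2)nn1-c1ccccc1)c1cccc(C(F)(F)F)c1` gives 1650 nM in this assay, and compound 2 `O=C(Nc1cc(-c2ccccc2)nn1-c1ccccc1)c1cccc([N+](=O)[O-])c1` gives 2220 nM. The step of a 3.8-fold lower number from compound 1 to compound 3 (0.58 log units; beyond the scatter) and the step of a 5.2-fold lower number from compound 2 to compound 3 (0.71 log units; beyond the scatter) are both modest yet beyond the scatter, whereas a 1.3-fold higher number from compound 1 to compound 2 (0.13 log units; within the scatter) lies within it, so the two substituted phenyl groups on the carbonyl carbon cannot be told apart on these numbers.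

Compound 4 `O=C(Nc1cc(-c2ccccc2)nn1-c1ccccc1)C1CCCC1` differs from compound 3 in one place: cyclopentyl in place of 3,4-dimethylphenyl on a carbonyl carbon. Among the compounds with values here, no measured pair exchanges an aromatic ring on the carbonyl carbon for a non-aromatic one, so the bearing of the earlier steps is indirect. Within the data shown here, they show only that changing the group on the carbonyl carbon has shifted this assay by modest amounts, as seen from compound 1 and compound 2 to compound 3. The loss of the aromatic ring is expected to cost some binding, so a modest rise in the number, a 3.0-fold higher number from compound 3 to compound 4 (0.48 log units; beyond the scatter), is expected. Compound 4 is thus estimated at 1300 nM in this assay, with a range from 400 nM to 4500 nM.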

Compound 4, inhibition constant: 11600 nM
Compound 4: the middle estimate sits 8.9-fold (0.95 log units) below what was measured, outside the stated range (above it).
By their numbers in this assay, from the lowest: compound 3; then compounds 1 and 2 (each within the scatter of the next); then compound 4.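

In this assay, this change shows that the group on the carbonyl carbon can move the number by a large step (a 27-fold higher number from compound 3 to compound 4 (1.43 log units; beyond the scatter)), whereas the earlier exchanges among substituted phenyl groups gave only modest steps or stayed within the scatter. The same replacement by cyclopentyl gives modest steps from the other two phenyl amides (a 5.2-fold higher number from compound 2 to compound 4 (0.72 log units; beyond the scatter)) and (a 7.0-fold higher number from compound 1 to compound 4 (0.85 log units; beyond the scatter)), so among the four compounds shown, all three with a six-membered aromatic ring on the carbonyl carbon give lower numbers than the one with a five-membered non-aromatic ring, and no compound shown goes against this. Nothing available bears on why the number rises this far.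

The compounds shown leave open whether the rise follows the loss of the aromatic ring or the drop in heavy atoms, as cyclopentyl changes both at once and is the only non-aromatic group on this carbonyl carbon. A cyclohexyl group, a benzyl group or a pyridine ring at this place would help to separate these two readings.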